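Selenol Replacement in the Shared Core: Notes on Compound 4

A few compounds are considered here, and "the series" means these few. Any claim that something is new, unique, unknown or untested is made for them only; others in the source may bear on it.

compound 1 `COc1ccc(CNc2nc([Se]C)nc3ccccc23)cc1`: > 100000 nM (a limit)
compound 2 `COc1ccc(CNc2nc([SeH])nc3ccccc23)cc1`: > 100000 nM (a limit)
compound 3 `CCCCC[Se]c1nc(NCc2ccc(SC)cc2)c2ccccc2n1`: > 100000 nM (a limit)

In a functional assay on HT-29 cells (Homo sapiens) for cytotoxicity, read by MTT assay, with a stated time of 72 h (a higher number here means a weaker inhibitor of growth, a lower number a stronger inhibitor of growth), compound 3 gives only a limit of the assay, > 100000 nM, so it stands at the limit and not at a number. Compound 4 `CSc1ccc(CNc2nc([SeH])nc3ccccc23)cc1` differs from compound 3 by hydrogen in place of pentyl on a selenium. Going by the values given here, the one measured step bearing on this change is a step that the two limits leave unreadable from compound 1 to compound 2, the same kind of removal of a chain from the selenium, and its size is not readable because of the limit of > 100000 nM in this assay, at which 3 of the 3 values shown sit. Nothing measured therefore points to a step beyond the scatter in this assay in either direction. For compound 4 the expected step is a step that the limit leaves unreadable from compound 3 to compound 4, flat within the scatter. Compound 4 is thus expected at 150000 nM, with a range of 50000 nM to 500000 nM, most likely reported again as a limit.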

Compound 4, concentration for total growth inhibition: > 100000 nM
Compound 4: a limit, no number (the forecaster's own chance of this, stated with the estimate: 85%); the middle value does not contradict the limit.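

No step can be read from compound 2 or compound 3 to compound 4, because all of these compounds stand at one limit: the limit of > 100000 nM in this assay, at which 4 of the 4 values shown sit. The compounds shown leave open what size either change would have on a measured number.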